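Replacing a Diethylamino Chain End with an Ether Chain

The compounds below may be only part of what the source reports. "The series", "measured", "known", "first", "only" and "open" are said of these compounds alone.

Measured compounds:
compound 1, `CCCCCCCN(CCCCCSc1nc(C2CCCCC2)c(C2CCCCC2)[nH]1)C(=O)Nc1ccc(F)cc1F`: 20 nM
compound 2, `CCN(CC)CCN(CCCCCSc1nc(-c2ccccc2)c(-c2ccccc2)[nH]1)C(=O)NC(C)C`: 660 nM

In an assay on microsomes from liver with sterol O-acyltransferase 1 (Rattus norvegicus) as the target (a lower number here means a stronger inhibitor, a higher number a weaker inhibitor), compound 1 gives 20 nM, and compound 2 gives 660 nM. Of the two numbers, compound 2 has the higher one, and the gap to compound 1 is beyond the usual scatter.

Compound 3, `CCOCCOCCN(CCCCCSc1nc(-c2ccccc2)c(-c2ccccc2)[nH]1)C(=O)NC(C)C`, has not been measured. It differs from compound 2 in one place: 2-ethoxyethoxy in place of diethylamino on a saturated chain carbon, two bonds along the chain from an amide-type nitrogen. Among the measured compounds shown here, no measured pair shows this kind of change, so only a modest step is expected in this assay, with a slight lean toward a weaker inhibitor, that is a 1.4-fold higher number from compound 2 to compound 3 (0.13 log units; within the scatter). Compound 3 is therefore estimated at 900 nM, ranging from 250 nM to 3000 nM.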

Compound 3, half-maximal inhibitory concentration: 30 nM
Beside the measured number, compound 3's estimate is 30-fold (1.48 log units) above it; measured number outside the range, below it.
By their numbers in this assay, from the lowest: compounds 1 and 3 (each within the scatter of the next); then compound 2.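

In this assay, among the compounds shown here, the end of this chain turns out to matter greatly: 2-ethoxyethoxy in place of diethylamino gives a 22-fold lower number from compound 2 to compound 3 (1.34 log units; beyond the scatter) and is the first sign of how much this position can change the number. A strong inhibitor here therefore does not need the diethylamino end. No available evidence explains the size of this step.

From the compounds shown here alone, whether the ether oxygens matter, or only the loss of diethylamino, stays open. A plain hexyl chain or a morpholine in the same place would help separate the two.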